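Urea series on HEK293 cytotoxicity: compound 3 to compound 4

The compounds below may be only part of what the source reports. "The series", "measured", "known", "first", "only" and "open" are said of these compounds alone.

Working notes on the series. In an ADME assay on HEK293 cells (Homo sapiens) for cytotoxicity, with a stated time of 72 h (on this read-out lower numbers stand for an effect already at smaller amounts and higher numbers for an effect only at larger amounts of compound), compound 3 `Cc1ccc(NC(=O)Nc2cc(C)nc3ccccc23)cc1` gives only a limit, > 25000 nM, so its value is not a number. Compound 1 `Cc1cc(NC(=O)Nc2ccc(C(=O)O)cc2)c2ccccc2n1` likewise gives only a limit in this assay, > 25000 nM. The step from compound 1 to compound 3, a step that the two limits leave unreadable from compound 1 to compound 3, is therefore unreadable, and the two limits together are what the limit of > 25000 nM in this assay, at which 2 of the 3 values shown sit, records. Within the data shown here, compound 2 `Cc1cc(NC(=O)Nc2cc(F)ccc2F)c2ccccc2n1` is the only member with a number in this assay, 12000 nM.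

Compound 4 `Cc1cc(NC(=O)Nc2ccccc2F)c2ccccc2n1` is not yet measured. It differs from compound 3 by 2-fluorophenyl in place of 4-methylphenyl on an amide-type nitrogen. No measured step bears directly on this change: the only step in the series leaves the aryl group on the amide-type nitrogen unchanged, and the fluorinated analogue compound 2 differs from compound 4 in one further fluorine, so no step between them is shown. Given that compound 2 carries a number in this assay while compound 3 sits at a limit, the change toward 2-fluorophenyl is expected to move compound 4 toward the region of compound 2, with the step of an at least 1.2-fold lower number from compound 3 to compound 4 (0.09 log units; that floor lies within the scatter) from compound 3 to compound 4 not readable in size. Compound 4 is estimated at 20000 nM in this assay, between 8000 nM and 50000 nM.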

Compound 4, half-maximal effective concentration: > 25000 nM
Compound 4: only a limit was reported; the forecaster's own chance of this, stated with the estimate: 45%; middle value at least 1.2-fold (0.09 log units) away from the limit.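

In this assay compound 4 gives only a limit, > 25000 nM, so it adds no number to the series. Among these compounds, with hydrogen in place of fluoro on an aromatic carbon, the series gains its first readable step, an at least 2.0-fold higher number from compound 2 to compound 4 (0.31 log units; beyond the scatter), which lies beyond the scatter and shows that one fluoro group separates the only number from a limit. The steps between limits cannot be read, so 2-fluorophenyl in place of 4-methylphenyl on the amide-type nitrogen has no measurable size here, and compound 1, compound 3 and compound 4 cannot be ordered: the limit of > 25000 nM in this assay, at which 3 of the 4 values shown sit.

Going by these compounds, whether the number seen for compound 2 is specific to the second fluoro group remains open, as does whether a chloro or methoxy group in its place would also give a number rather than a limit. On these data alone, how much higher the true values of compound 1, compound 3 and compound 4 lie than the limit of the assay also remains open, and any difference among them stays unresolved.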